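The source may hold more compounds than are shown below. What is called first, only, known or untested is meant among the compounds shown, and "the series" means these compounds.

In a functional assay on P388 cells (Mus musculus) for antiproliferative activity, read by colorimetric assay and MTT assay (a higher number here means a weaker inhibitor, a lower number a stronger inhibitor), compound 1 (`O=S(=O)(Nc1cccc2cc[nH]c12)c1ccc(Cl)cc1`) gives 6 ug/mL and compound 2 (`O=S(=O)(Nc1cccc2c(Cl)c[nH]c12)c1ccc(Cl)cc1`) gives 4.3 ug/mL on the same read-out. Within the data shown here, these two values lie within the scatter of each other, and the one measured step between them is a 1.4-fold lower number from compound 1 to compound 2 (0.14 log units; within the scatter) with nothing larger to compare. Compound 3 (`O=[N+]([O-])c1ccc(S(=O)(=O)Nc2cccc3c(Cl)c[nH]c23)cc1`) carries nitro in place of chloro on an aromatic carbon, para to a large group (nitro in place of chloro on an aromatic carbon). Among the measured compounds shown here, no measured step makes this change. For the measured compounds named here, the one step available is a different change, chloro in place of hydrogen on an aromatic carbon, and it stayed within the scatter, so it offers only weak guidance. In this assay no step beyond the scatter is therefore expected, in either direction. The estimated change is a 1.2-fold lower number from compound 2 to compound 3 (0.09 log units; within the scatter) and carries wide uncertainty. Compound 3 is expected at 3.5 ug/mL within an estimated range of 1 ug/mL to 12 ug/mL on this read-out.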

Compound 3, half-maximal inhibitory concentration: 2.3 ug/mL
For compound 3 the middle estimate is 1.5-fold (0.18 log units) above the measured one; the range from low to high includes it.
By their numbers in this assay, from the lowest: compounds 3, 2 and 1 (each within the scatter of the next, the first and the last beyond it).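

Among these compounds, the step of a 1.9-fold lower number from compound 2 to compound 3 (0.27 log units; within the scatter) in this assay is the first reading of any change at this position, on an aromatic carbon para to a large group, since the earlier compounds both carry chloro there. It shows that chloro, a single chlorine, can give way to nitro, with its three heavy atoms and two hydrogen-bond acceptors, without a step beyond the scatter. Nothing measured here bears on why the step has this size.

With only chloro and nitro at this position, the compounds shown cannot establish a trend across groups. On these data alone, it remains open whether an amine, a carboxylic acid or a longer chain in the same place would stay within the scatter or move beyond it.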